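This account rests on a few compounds, and the source may have more. Where it says the series, first, only, none or still open, it means among the compounds named here.

In an ADME assay for permeability, using PAMPA, at pH 7.4 (a higher number here means that the compound crosses the layer faster, a lower number that the compound crosses the layer more slowly), compound 1 (`CCN(C[C@H]1Cc2c(cccc2N2CCNCC2)CN1)[C@H]1CCCc2cccnc21`) gives 75 nm/s, the lower of the two numbers available, while compound 2 (`CN1CCN(c2cccc3c2C[C@H](CN(C)[C@H]2CCCc4cccnc42)NC3)CC1`) gives 996 nm/s, a gap beyond the scatter. Compound 3 (`c1cnc2c(c1)CCC[C@@H]2N(CC1CCCCC1)C[C@H]1Cc2c(cccc2N2CCNCC2)CN1`) departs from compound 1 in one place: cyclohexyl in place of methyl on a saturated chain carbon bound to an amine nitrogen. Within the data shown here, no measured pair isolates this change, so any expectation remains tentative. A moderate rise is expected in this assay, with an estimated step of a 2.7-fold higher number from compound 1 to compound 3 (0.43 log units; beyond the scatter). The estimated value for compound 3 is 200 nm/s, within an expected range of 70 nm/s to 600 nm/s.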

Compound 3, apparent permeability: 9 nm/s
Compound 3: the middle estimate sits 22-fold (1.35 log units) above what was measured, outside the stated range (below it).
By their numbers in this assay, from the lowest: compound 3; then compound 1; then compound 2.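

In this assay, cyclohexyl in place of methyl on a saturated chain carbon bound to an amine nitrogen gives an 8.3-fold lower number from compound 1 to compound 3 (0.92 log units; beyond the scatter). This place on the core of compound 1 therefore responds strongly to the change, and the larger group goes with a lower number rather than a higher one. Nothing available accounts for this step. On these data alone, whether a cyclopropyl group, a longer open chain or a tetrahydropyranyl ring at this place would give a similar step remains open.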